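The source may hold more compounds than are shown below. What is called first, only, known or untested is meant among the compounds shown, and "the series" means these compounds.

Compounds measured in an assay on membranes from HEK293 cells for displacement of a labelled ligand from Type-2 angiotensin II receptor (Homo sapiens), read by radioligand binding; a lower number here means a stronger inhibitor, a higher number a weaker inhibitor:

- compound 1, `CCCCOC(=O)NS(=O)(=O)c1ccc(CCC)cc1-c1ccc(Cn2c(CC(C)C)nc3ccccc32)cc1`, giving 19 nM
- compound 2, `CCCc1ccc(S(=O)(=O)NC(=O)OCCCC(F)(F)F)c(-c2cc(F)c(Cn3c(C(C)(C)C)nc4ccccc43)c(F)c2)c1`, giving 12 nM
- compound 3, `CCCCOC(=O)NS(=O)(=O)c1ccc(CCC)cc1-c1ccc(Cn2c(C3CCC3)nc3ccccc32)cc1`, giving 12 nM

Compound 1 stands at the highest of the three numbers in this assay, but its nearest neighbour, compound 2, and its furthest, compound 3, both lie within the usual scatter of it, so no order among the three can be read from these values. Within the data shown here, the only single-point step among the measured compounds runs a 1.6-fold lower number from compound 1 to compound 3 (0.20 log units; within the scatter); compound 2 differs from compound 1 in several places at once, and its value is simply seen to sit close to that of compound 1.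

Compound 4, `CCCCOC(=O)NS(=O)(=O)c1ccc(CCC)cc1-c1ccc(Cn2c(CCC)nc3ccccc32)cc1`, has not yet been measured in this assay. It differs from compound 1 in one place: hydrogen in place of methyl on a saturated chain carbon bound to two saturated chain carbons. Among the measured compounds shown here, the one step that bears on this change, from compound 1 to compound 3, reworks the same saturated group and stays within the scatter, and compound 2, with yet another variant at that position, also stays close. On that basis only a small step in this assay is expected, if any, most likely a slightly higher number. The estimated step from compound 1 to compound 4 is a 1.3-fold higher number from compound 1 to compound 4 (0.12 log units; within the scatter). Compound 4 is therefore expected to give about 25 nM, in a range from 10 nM to 60 nM.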

Compound 4, inhibition constant: 14 nM
Compound 4: middle estimate off by 1.8-fold (0.25 log units), on the high side, within the range that was stated.
By their numbers in this assay, from the lowest: compounds 2, 3, 4 and 1 (each within the scatter of the next).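

Dropping the methyl on a saturated chain carbon bound to two saturated chain carbons turns isobutyl into propyl and gives in this assay a 1.4-fold lower number from compound 1 to compound 4 (0.13 log units; within the scatter), so removing this methyl has no effect that can be read here. Propyl in place of cyclobutyl on an aromatic carbon gives a 1.2-fold higher number from compound 3 to compound 4 (0.07 log units; within the scatter), so the open chains and the ring in compounds 1, 3 and 4 cannot be told apart at this place, and the position accepts all three groups within this set. No information beyond the binding numbers bears on this result.

The compounds shown leave open how far this tolerance extends, since a methyl, a longer chain such as hexyl, a phenyl ring or an amine on the same aromatic carbon could give a quite different number. They also leave open whether the same insensitivity would hold with other parts of the core of compound 4 changed, for example with a carboxylic acid in place of the butyl carbamate.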